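Trading a 4-(trifluoromethyl)benzyl for hydrogen on a ring nitrogen

This account rests on a few compounds, and the source may have more. Where it says the series, first, only, none or still open, it means among the compounds named here.

compound 1 `CC(C)(C)NCc1cc(Cl)cc(Nc2nc3ccccc3n2Cc2ccc(C(F)(F)F)cc2)c1O`: 36300 nM
compound 2 `CCN(CC)Cc1cccc(Nc2nc3ccccc3[nH]2)c1O`: > 50000 nM
compound 3 `CCN(CC)Cc1cccc(Nc2nc3ccccc3n2Cc2ccc(C(F)(F)F)cc2)c1O`: > 50000 nM

Of the compounds shown here, three have been tested in an ADME assay on CHO cells (Cricetulus griseus) for inhibition, read by MTT assay; on this read-out lower numbers stand for stronger inhibition and higher numbers for weaker inhibition. Among the compounds with values here, compound 1 is the only one to return a number, giving 36300 nM in this assay. For compound 2 the result is a limit of the assay, > 50000 nM. For compound 3 the result is likewise a limit, > 50000 nM. Compound 3 and compound 2 differ by hydrogen in place of 4-(trifluoromethyl)benzyl on an aromatic nitrogen, and the step between them, a step that the two limits leave unreadable from compound 3 to compound 2, cannot be sized because both ends sit at the limit of > 50000 nM in this assay, at which 2 of the 3 values shown sit.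

Compound 4 `CC(C)(C)NCc1cc(Cl)cc(Nc2nc3ccccc3[nH]2)c1O` has not yet been measured. It stands to compound 1 as compound 2 stands to compound 3: the change is hydrogen in place of 4-(trifluoromethyl)benzyl on an aromatic nitrogen, the same change at the same place. The difference between the core of compound 1 and the core of compound 3 is not broken down here.

Within the data shown here, the one measured example of this change is unreadable, so the expectation for compound 4 rests mainly on compound 1 itself, whose value 36300 nM is already weak. The step from compound 1 to compound 4 is therefore expected to be small, a 1.4-fold higher number from compound 1 to compound 4 (0.14 log units; within the scatter), with a real chance that only a limit is reported. Compound 4 is estimated at 50000 nM in this assay, expected to lie between 18000 nM and 150000 nM.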

Compound 4, half-maximal inhibitory concentration: > 50000 nM
Compound 4 gave a limit, no number; the forecaster's own chance of this, stated with the estimate: 60%; the middle value sits exactly at the limit.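

In this assay, hydrogen in place of 4-(trifluoromethyl)benzyl on the core of compound 1 gives an at least 1.3-fold higher number from compound 1 to compound 4 (0.13 log units; that floor lies within the scatter), so the change can be read on this core only as a floor, and that floor does not show a real loss of inhibition, although a larger step remains possible. Within the data shown here, on the other core the same change cannot be sized, as compound 3 and compound 2 both stand at a limit of the assay and not at a number: the limit of > 50000 nM in this assay, at which 3 of the 4 values shown sit. What the two cores share is therefore only that each compound without the benzyl group returns a limit, which fits a carry-over of the change from one core to the other but does not show that the step has the same size on both.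

The compounds shown leave open whether a plain benzyl, a methyl or a longer chain such as hexyl on that ring nitrogen would give a number in this assay, and so how much of the 4-(trifluoromethyl)benzyl the read-out depends on. They also leave open how the tert-butylamine and the chlorine of compound 1 each contribute, as these two differences from compound 3 are not separated by any compound here.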